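A few compounds are considered here, and "the series" means these few. Any claim that something is new, unique, unknown or untested is made for them only; others in the source may bear on it.

Working notes on the series. Compound 1 `Cc1cccc(NC(=O)Nn2c(-c3ccccc3)nc3ccccc3c2=O)c1` gives 59% in a functional assay on the whole organism (strain albino) with Mus musculus as the target, at a dose of 100 mg/kg by the intraperitoneal route; a higher number here means more inhibition at the dose given (going by the name of the read-out), a lower number less inhibition. Compound 2 `Cc1ccccc1NC(=O)Nn1c(-c2ccccc2)nc2ccccc2c1=O` gives 59% in this assay. The change between them, (2-methylphenyl in place of 3-methylphenyl on an amide-type nitrogen), produced no change at the digits printed from compound 1 to compound 2 (within the scatter). Compound 3 `CCc1nc2ccccc2c(=O)n1NC(=O)Nc1cccc(C)c1` gives 53% in this assay; its core differs from the core of compound 1 by ethyl in place of phenyl on an aromatic carbon, and that change gave a number 6 percentage points lower from compound 1 to compound 3 (within the scatter). Compound 4 `CCc1nc2ccccc2c(=O)n1NC(=O)Nc1ccccc1C` has not yet been measured in this assay. It differs from compound 3 by 2-methylphenyl in place of 3-methylphenyl on an amide-type nitrogen, the same change as from compound 1 to compound 2, at a place described in identical words, so it is treated as the same change made on the other core. For compound 4 the expected step is no change at the digits printed from compound 3 to compound 4 (within the scatter), which rests on the earlier pair, where the same change gave no change at the digits printed from compound 1 to compound 2 (within the scatter), and on compound 3 standing at 53%. Compound 4 is therefore estimated to give 53% in this assay, with an expected range from 40% to 66% that allows for the usual scatter. The measured number will settle it.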

Compound 4, a percentage reported as inhibition, in the whole organism at one dose (the size of the read-out at that dose, not a potency): 54%
Estimate against measurement, compound 4: 1 percentage points below; the measured number falls inside the stated range.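

In this assay, 2-methylphenyl in place of 3-methylphenyl on an amide-type nitrogen, carried to the core of compound 3, gave a number 1 percentage points higher from compound 3 to compound 4 (within the scatter), and the change reads alike on both cores: the same change on two cores in this assay, no change at the digits printed (within the scatter) from compound 1 to compound 2 and a number 1 percentage points higher (within the scatter) from compound 3 to compound 4, 1 percentage points apart, within the scatter of two such steps

Ethyl in place of phenyl on an aromatic carbon, read with 2-methylphenyl in place, gave a number 5 percentage points lower from compound 2 to compound 4 (within the scatter), and this change also reads alike in both settings: the same change on two cores in this assay, a number 6 percentage points lower (within the scatter) from compound 1 to compound 3 and a number 5 percentage points lower (within the scatter) from compound 2 to compound 4, 1 percentage points apart, within the scatter of two such steps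

Going by these compounds alone, all four steps lie within the scatter, which shows only that neither change moved the read-out beyond it in these two settings; it does not show that a change giving a large step would carry over in the same way, and a single-dose read-out gives no potency.

The compounds shown leave open whether the read-out would hold with a carboxylic acid or an amine in place of the methyl on the phenyl ring. They also leave open what a longer chain such as butyl would give in place of ethyl.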